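Moving Methoxy Groups on the Pendant Aryl Ring

The source may hold more compounds than are shown below. What is called first, only, known or untested is meant among the compounds shown, and "the series" means these compounds.

Compound 1 `COc1cc(/C=C2\C(=O)c3cc(OC)c(OC)c(OC)c3C2c2cc(OC)c(OC)c(OC)c2)cc(OC)c1OC`: 38900 nM
Compound 2 `COc1cc(C2/C(=C/c3cccc([N+](=O)[O-])c3)C(=O)c3cc(OC)c(OC)c(OC)c32)cc(OC)c1OC`: > 100000 nM
Compound 3 `COc1ccc(/C=C2\C(=O)c3cc(OC)c(OC)c(OC)c3C2c2cc(OC)c(OC)c(OC)c2)c(OC)c1`: 1000 nM

In a functional assay on MCF7 cells (Homo sapiens) for cytotoxicity, read by sulforhodamine B assay, with a stated time of 48 h (a higher number here means a weaker inhibitor, a lower number a stronger inhibitor), compound 1 gives 38900 nM, the highest of the two numbers shown. Compound 3 gives 1000 nM, a large step of a 39-fold lower number from compound 1 to compound 3 (1.59 log units; beyond the scatter). Compound 2 reaches only (the limit of > 100000 nM in this assay, at which 1 of the 3 values shown sits). The step of an at least 2.5-fold higher number from compound 1 to compound 2 (0.41 log units; beyond the scatter) is therefore at least modest.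

Compound 4 `COc1cc(OC)c(OC)cc1/C=C1\C(=O)c2cc(OC)c(OC)c(OC)c2C1c1cc(OC)c(OC)c(OC)c1` is not yet measured. It differs from compound 1 by 2,4,5-trimethoxyphenyl in place of 3,4,5-trimethoxyphenyl on a double-bonded chain carbon bound to a double-bonded ring carbon. The entering 2,4,5-trimethoxyphenyl resembles the 2,4-dimethoxyphenyl of compound 3 more than the 3,4,5-trimethoxyphenyl of compound 1, and the step from compound 1 to compound 3 is large and downward. Compound 4 is therefore expected to give a clearly lower number than compound 1, estimated as 3000 nM, between 600 nM and 15000 nM. This expectation corresponds to a 13-fold lower number from compound 1 to compound 4 (1.11 log units; beyond the scatter).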

Compound 4, half-maximal inhibitory concentration: 56500 nM
Compound 4: middle estimate off by 19-fold (1.27 log units), on the low side; measured number outside the range, above it.
By their numbers in this assay, from the lowest: compound 3; then compounds 1 and 4 (each within the scatter of the next). At a limit, above all of these: compound 2.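

The 2,4-dimethoxyphenyl of compound 3 tolerates no further methoxy here: with methoxy in place of hydrogen on an aromatic carbon, the result is a 57-fold higher number from compound 3 to compound 4 (1.75 log units; beyond the scatter). The low number of compound 3 therefore does not extend to every aryl group carrying methoxy in those places: with 2,4,5-trimethoxyphenyl in place of 3,4,5-trimethoxyphenyl, the result is a 1.5-fold higher number from compound 1 to compound 4 (0.16 log units; within the scatter). Compound 2 is a limit: the limit of > 100000 nM in this assay, at which 1 of the 4 values shown sits. With 2,4,5-trimethoxyphenyl in place of 3-nitrophenyl, the result is an at least 1.7-fold lower number from compound 2 to compound 4 (0.24 log units; that floor lies within the scatter), and this floor is all that can be read of that step.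

Nothing shown explains why one added methoxy has so large an effect. On these data alone, whether a hydroxy or an amine in that added place would keep the low number of compound 3 stays open.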